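Swapping the thiourea aryl group in a cytotoxicity series

The source may hold more compounds than are shown below. What is called first, only, known or untested is meant among the compounds shown, and "the series" means these compounds.

Compound 3 `O=C(c1cc(Oc2cccc(NC(=S)Nc3cccc(C(F)(F)F)c3)c2)ccn1)N1CCCC1` was tested in a functional assay on PC-3 cells (Homo sapiens) for cytotoxicity, read by MTT assay, with a stated time of 48 h (on this read-out lower numbers stand for stronger inhibition and higher numbers for weaker inhibition), where compound 3 gives 27000 nM. Compound 1 `CNC(=O)c1cc(Oc2cccc(NC(=S)Nc3cccc(C(F)(F)F)c3)c2)ccn1` gives 24500 nM and compound 2 `O=C(NC1CC1)c1cc(Oc2cccc(NC(=S)Nc3cccc(C(F)(F)F)c3)c2)ccn1` gives 22100 nM; the step of a 1.1-fold lower number from compound 1 to compound 2 (0.04 log units; within the scatter), the step of a 1.1-fold higher number from compound 1 to compound 3 (0.04 log units; within the scatter) and the step of a 1.2-fold higher number from compound 2 to compound 3 (0.09 log units; within the scatter) all stay within the scatter, so compound 3 sits level with the other two rather than apart from them. Compound 4 `O=C(c1cc(Oc2cccc(NC(=S)Nc3ccc(OC(F)(F)F)cc3)c2)ccn1)N1CCCC1` differs from compound 3 by 4-(trifluoromethoxy)phenyl in place of 3-(trifluoromethyl)phenyl on an amide-type nitrogen. Within the data shown here, none of the measured steps touches this part of the molecule; all three alter the group on the carbonyl carbon instead, so they offer no direction for this change. Compound 4 is therefore expected to show a step of no change at the digits printed from compound 3 to compound 4 (within the scatter) that stays within the scatter, giving an estimate of 27000 nM in this assay, with a range from 9000 nM to 80000 nM.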

Compound 4, half-maximal inhibitory concentration: 34100 nM
Compound 4: the middle estimate sits 1.3-fold (0.10 log units) below what was measured; low and high end bracket the measured number.
By their numbers in this assay, from the lowest: compounds 2, 1, 3 and 4 (each within the scatter of the next).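

Where the earlier compounds varied only the group on the carbonyl carbon, compound 4 alters the aryl group on the amide-type nitrogen, and this assay gives a 1.3-fold higher number from compound 3 to compound 4 (0.10 log units; within the scatter). Exchanging 3-(trifluoromethyl)phenyl for 4-(trifluoromethoxy)phenyl, which adds one oxygen, therefore leaves compound 4 level with compound 3 on this read-out. Nothing available gives a reason for this result.

Still open, as far as these compounds go, is whether this nitrogen would respond to a very different group, such as a phenyl ring carrying a carboxylic acid or an amine. From the compounds shown here alone, because the substituent and its printed ring number change together, their separate contributions also remain unknown.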